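The source may report more compounds than this note shows. Statements on the series, on what has been measured and on what is new or still open speak of the compounds shown alone.

Compound 1, `CSC(CCC/C=C(\c1ccccc1)c1cccnc1)C(=O)O`: 30 nM in an assay (Equus caballus) for inhibition of Thromboxane-A synthase (Homo sapiens), using microsomes; a higher number here means a weaker inhibitor, a lower number a stronger inhibitor.
Compound 2, `O=C(O)CCCC/C=C\c1cccnc1`: 250 nM.
Compound 3, `COc1ccc(/C(=C/CCCCC(=O)O)c2cccnc2)cc1`: 80 nM.

Among these three measured compounds, compound 1 shows the lowest number, and so the strongest inhibition. Compound 3 stands nearest to it, yet its number lies higher by more than the usual scatter of the test; compound 2 stands furthest, also well beyond the scatter. Compound 1 is therefore the reference point for the next compound.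

Compound 4, `COCC(CCC/C=C(\c1ccccc1)c1cccnc1)C(=O)O`, has not yet been measured. It differs from compound 1 in a single place: methoxymethyl in place of methylsulfanyl on a saturated chain carbon bound to a carbonyl carbon and a saturated chain carbon. For the measured compounds named here, no measured pair in this set shows what such a swap does, so the outlook rests on the shared remainder of the structure, which stays untouched. The step expected from compound 1 to compound 4 is a 1.7-fold higher number from compound 1 to compound 4 (0.22 log units; within the scatter), a modest move toward a higher number that may well stay within the scatter. Compound 4 is accordingly expected to give 50 nM, within a range from 15 nM to 160 nM.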

Compound 4, half-maximal inhibitory concentration: 41 nM
Compound 4: the middle estimate sits 1.2-fold (0.09 log units) above what was measured; measured number inside the range.
By their numbers in this assay, from the lowest: compounds 1, 4 and 3 (each within the scatter of the next, the first and the last beyond it); then compound 2.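

The step for methoxymethyl in place of methylsulfanyl, on a saturated chain carbon bound to a carbonyl carbon and a saturated chain carbon, is a 1.4-fold higher number from compound 1 to compound 4 (0.14 log units; within the scatter) in this assay. For the compounds shown here, this is the first direct comparison at this position, and it shows that the two groups cannot be told apart in this test. For this one replacement, then, the sulfur atom of compound 1 is not needed to keep a number of this size, although nothing shown explains the result.

Still open, on these data alone, is how other groups at this place would read, such as an amine, a hydroxymethyl or a longer chain. Also open, as far as these compounds go, is whether a plain hydrogen there would give a number like those of compound 1 and compound 4.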